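A few compounds are considered here, and "the series" means these few. Any claim that something is new, unique, unknown or untested is made for them only; others in the source may bear on it.

In a functional assay on UACC-257 cells (Homo sapiens) for inhibition, read by sulforhodamine B assay, with a stated time of 48 h (on this read-out lower numbers stand for higher toxicity in this test and higher numbers for lower toxicity in this test), compound 1 `CCOC(=O)[C@H](CCC(=O)O)NC(=O)c1ccc(CNc2nc3cc(N)cc(N)c3nc2-c2ccccc2)cc1` gives 69200 nM. Compound 2 `Nc1cc(N)c2nc(-c3ccccc3)c(NCc3ccc(Cl)c(Cl)c3)nc2c1` gives in this assay a value of 43700 nM, and the two numbers lie within the usual scatter of each other, so on these two measurements compound 2 cannot be told apart from compound 1. Compound 3 `COc1ccc(CNc2nc3cc(N)cc(N)c3nc2-c2ccccc2)cc1OC` has not yet been measured in this assay; it differs from compound 2 in one place: 3,4-dimethoxyphenyl in place of 3,4-dichlorophenyl on a saturated chain carbon bound to a nitrogen on an aromatic ring. Within the data shown here, no measured pair in this set shows what this exchange does, so the expectation rests only on compound 2 and its value 43700 nM. The step from compound 2 to compound 3 is expected to be small, most likely a modest rise in the number or none beyond the scatter, as a 1.4-fold higher number from compound 2 to compound 3 (0.14 log units; within the scatter). For compound 3 in this assay the estimate is 60000 nM, with a range from 25000 nM to 150000 nM.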

Compound 3, concentration lethal to 50% of the cells: 55000 nM
For compound 3 the middle estimate is 1.1-fold (0.04 log units) above the measured one; the measured number falls inside the stated range.
By their numbers in this assay, from the lowest: compounds 2, 3 and 1 (each within the scatter of the next).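

Among these compounds, this is the first exchange at this place, on a saturated chain carbon bound to a nitrogen on an aromatic ring, that can be read in this assay: 3,4-dimethoxyphenyl in place of 3,4-dichlorophenyl gives a 1.3-fold higher number from compound 2 to compound 3 (0.10 log units; within the scatter). The entering group carries hydrogen-bond acceptors and the leaving group none, yet this pair stays within the scatter, so the exchange does not separate the two compounds on this read-out. Nothing available here accounts for this outcome.

Still open, on these data alone, is whether a single methoxy or a single chlorine on this phenyl ring would likewise leave the number within the scatter. As far as these compounds go, it is equally open whether an amine or a carboxylic acid on that ring, or a longer chain in place of the saturated chain carbon, would give a step beyond it.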